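This account rests on a few compounds, and the source may have more. Where it says the series, first, only, none or still open, it means among the compounds named here.

In a functional assay on MDA-MB-231 cells (Homo sapiens) for cytotoxicity, read by MTT assay, with a stated time of 72 h (on this read-out higher numbers stand for weaker inhibition and lower numbers for stronger inhibition), compound 2, whose structure is `O=C1c2c[n+]([O-])c3ccccc3c2C(=O)c2c1c1ccccc1n2Cc1cn(C[C@H](O)CO)nn1`, gives 1310 nM, the lowest of the two plain numbers shown. Compound 1, with structure `O=C1c2c[n+]([O-])c3ccccc3c2C(=O)c2c1c1ccccc1n2Cc1cn([C@H]2O[C@H](CO)[C@@H](O)[C@H]2O)nn1`, gives 1700 nM; the step of a 1.3-fold lower number from compound 1 to compound 2 (0.11 log units; within the scatter) lies within the scatter, so the two compounds cannot be told apart. Compound 3, with structure `CC1(C)OC[C@@H](Cn2cc(Cn3c4c(c5ccccc53)C(=O)c3c[n+]([O-])c5ccccc5c3C4=O)nn2)O1`, gives > 1000 nM, which is a limit of the assay and not a number. Because of the limit of > 1000 nM in this assay, at which 1 of the 3 values shown sits, the steps a step that the limit leaves unreadable from compound 1 to compound 3 and a step that the limit leaves unreadable from compound 2 to compound 3 cannot be sized.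

Compound 4, structure `CN1CCN(CCCCCCn2c3c(c4ccccc42)C(=O)c2c[n+]([O-])c4ccccc4c2C3=O)CC1`, is not yet measured. It differs from compound 2 in one place: 5-(4-methylpiperazin-1-yl)pentyl in place of 1-(2,3-dihydroxypropyl)-1H-1,2,3-triazol-4-yl on a saturated chain carbon bound to an aromatic nitrogen. Among the measured compounds shown here, the only readable step, from compound 1 to compound 2, swaps one hydroxylated group for another and is within the scatter; no measured step exchanges the whole triazole-bearing group for a basic amine chain, so none bears directly on this change. The estimate for compound 4 therefore stays near its neighbours, with a wide range: compound 4 is expected to give about 900 nM, between 250 nM and 3000 nM, meaning an estimated step of a 1.5-fold lower number from compound 2 to compound 4 (0.16 log units; within the scatter).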

Compound 4, half-maximal inhibitory concentration: 2400 nM
Beside the measured number, compound 4's estimate is 2.7-fold (0.43 log units) below it; the range from low to high includes it.
By their numbers in this assay, from the lowest: compounds 2, 1 and 4 (each within the scatter of the next).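

In this assay, among the compounds shown here, this is the first measured change that replaces the whole 1-(2,3-dihydroxypropyl)-1H-1,2,3-triazol-4-yl group on a saturated chain carbon bound to an aromatic nitrogen, and it gives a 1.8-fold higher number from compound 2 to compound 4 (0.26 log units; within the scatter). The earlier readable step only swapped one hydroxylated group for another, whereas here the triazole ring, the hydroxyl groups and the stereocentre all leave and a 5-(4-methylpiperazin-1-yl)pentyl group enters. Even so different a group at this place gives a number that cannot be told apart from that of compound 2.

Compound 3 has a limit and not a plain number, so its steps cannot be read: the limit of > 1000 nM in this assay, at which 1 of the 4 values shown sits. On these data alone, whether a carboxylic acid, or a shorter chain carrying a primary amine, would give a step beyond the scatter at this place stays open.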